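The compounds below may be only part of what the source reports. "The series", "measured", "known", "first", "only" and "open" are said of these compounds alone.

Compound 1: `COc1cccc(/C=N\NC(=O)C2=C(Cl)c3ccccc3CCC2)c1` gives 15600 nM
Compound 2: `COc1cc(/C=N\NC(=O)C2=C(Cl)c3ccccc3CCC2)cc(OC)c1OC` gives 8200 nM

Both compounds were tested in a functional assay on HeLa cells (Homo sapiens) for inhibition, read by sulforhodamine B assay, with a stated time of 48 h; on this read-out higher numbers stand for weaker inhibition of growth and lower numbers for stronger inhibition of growth. Among the measured compounds shown here, of the two numbers, the one for compound 1 is the larger, but its gap to compound 2 lies within the usual scatter of repeated measurements, so the two cannot be told apart on this read-out; both stand at the weak end of inhibition of growth.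

Compound 3 is `O=C(N/N=C\c1ccc(F)cc1)C1=C(Cl)c2ccccc2CCC1`, which has not yet been measured. It differs from compound 1 in one place: 4-fluorophenyl in place of 3-methoxyphenyl on a carbon with a double bond to nitrogen. The rest of the shared core, with its hydrazone and its chlorinated ring system, stays unchanged.

For the measured compounds named here, no measured pair shows what this particular swap does in this assay, so there is nothing to lean on beyond the two numbers above, which themselves differ only within the scatter. The most cautious expectation is therefore a step from compound 1 to compound 3 of no more than the scatter, in either direction. On that basis compound 3 is estimated at 12000 nM, with a range from 4000 nM to 40000 nM, which corresponds to an expected step of a 1.3-fold lower number from compound 1 to compound 3 (0.11 log units; within the scatter).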

Compound 3, concentration for 50% growth inhibition: 1300 nM
Estimate against measurement, compound 3: 9.2-fold (0.97 log units) above; measured number outside the range, below it.
By their numbers in this assay, from the lowest: compound 3; then compounds 2 and 1 (each within the scatter of the next).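

The group on the carbon with a double bond to nitrogen turns out to matter a great deal in this assay: with the rest of the shared core unchanged, 4-fluorophenyl in place of 3-methoxyphenyl gives a 12-fold lower number from compound 1 to compound 3 (1.08 log units; beyond the scatter), a step well beyond the scatter of repeated measurements. The two earlier numbers both sat at the weak end of inhibition of growth and gave no sign that a change at this position could move the result so far. Nothing measured here says why the number falls by so much.

The compounds shown leave open whether the step comes from the fluorine that enters or from the methoxy group that leaves, since both changes happen at once, and a plain phenyl group at this position would help to pull the two apart. They also leave open how quite different groups would behave here, such as a pyridine ring or a phenyl ring carrying an amine or a carboxylic acid.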